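A few compounds are considered here, and "the series" means these few. Any claim that something is new, unique, unknown or untested is made for them only; others in the source may bear on it.

Compound 1 `Nc1nc(O)c2c(n1)n(C1OC(CO)[C@@H](O)[C@H]1O)c(=O)n2C/C=C/c1ccccc1` is one of three compounds tested in a functional assay on the whole organism (B cells) with Mus musculus as the target; on this read-out lower numbers stand for smaller maximal responses and higher numbers for larger maximal responses. Compound 1 gives 73%, the second highest of the three numbers. Compound 3 `C=CCn1c(=O)n(CCCC)c2nc(N)nc(O)c21` gives 77%, within the scatter of compound 1, and compound 2 `C=CCn1c(=O)n(C2CCC(CO)C2)c2nc(N)nc(O)c21` gives 26%, well below compound 1. Within the data shown here, the only single-point step measured, a number 51 percentage points higher from compound 2 to compound 3 (beyond the scatter), swaps a group on an aromatic nitrogen and does not touch the chain carbon changed here. Compound 4 `CCCCCCCCCCn1c(=O)n(C2OC(CO)[C@@H](O)[C@H]2O)c2nc(N)nc(O)c21` differs from compound 1 in one place: nonyl in place of 2-phenylethenyl on a saturated chain carbon bound to an aromatic nitrogen. Among the measured compounds shown here, no measured step bears on this change, so the expectation rests on compound 1 alone, and no step beyond the scatter is expected in either direction. Compound 4 is therefore expected to give roughly 65%, between 35% and 90%, an expected step of a number 8 percentage points lower from compound 1 to compound 4 (within the scatter).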

Compound 4, largest response reached (reported as maximal response), in percent of the reference or control that the assay uses: 0%
The estimate for compound 4 lay 65 percentage points above the measured number, outside the stated range (below it).
By their numbers in this assay, from the lowest: compound 4; then compound 2; then compounds 1 and 3 (each within the scatter of the next).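

In this assay, putting nonyl in place of 2-phenylethenyl on a saturated chain carbon bound to an aromatic nitrogen gives a number 73 percentage points lower from compound 1 to compound 4 (beyond the scatter). This place, untouched by the earlier step, is therefore far from indifferent to its group: in this one pair, the long saturated chain leaves no response, although it has almost as many heavy atoms as the group it replaces. Nothing available explains this loss. As far as these compounds go, it remains open whether the ring, the double bond or the chain length decides the outcome. 2-Phenylethyl would keep the ring without the double bond, and butyl would show how a shorter chain behaves here.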